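This account rests on a few compounds, and the source may have more. Where it says the series, first, only, none or still open, it means among the compounds named here.

Measured so far:
compound 1 `CC(C)N(Cc1cccc(OCCCCCC(=O)O)c1)C(=O)c1ccc(-c2ccco2)cc1` — > 26000 nM
compound 2 `CCOC(=O)CCCCCOc1cccc(CN(C(=O)c2ccc(-c3cccnc3)cc2)C(C)C)c1` — > 26000 nM

In an ADME assay on HEK293 cells (Homo sapiens) for cytotoxicity, read by CellTiter-Glo and resazurin assay, with a stated time of 72 h (on this read-out lower numbers stand for an effect already at smaller amounts and higher numbers for an effect only at larger amounts of compound), compound 1 gives > 26000 nM, which is a limit of the assay and not a number. Compound 2 gives > 26000 nM in this assay, also a limit. Among the measured compounds shown here, compound 2 thus stands at the limit of > 26000 nM in this assay, at which 2 of the 2 values shown sit; no measured step between the two compounds can be drawn, both simply sit at the limit.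

Compound 3 `CCOC(=O)CCCCCOc1cccc(CN(C(=O)c2ccc(-c3ccc4[nH]ccc4c3)cc2)C(C)C)c1` remains to be measured in this assay. It differs from compound 2 by 1H-indol-5-yl in place of pyridin-3-yl on an aromatic carbon. For the measured compounds named here, with both measured values at the limit, no measured step in this assay guides the expectation for this change. In this assay the expected change is a number no higher from compound 2 to compound 3 (the limit leaves the size open), none beyond the scatter, and a reading that is again only a limit is the most likely outcome. For compound 3 in this assay the estimated value is 26000 nM, with a range from 13000 nM to 60000 nM.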

Compound 3, half-maximal effective concentration: > 26000 nM
Compound 3 was reported as a limit (the forecaster's own chance of this, stated with the estimate: 70%); the middle value sits exactly at the limit.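

Compound 2 and compound 3 are both reported only as limits in this assay, not as numbers, so no step can be read between them. The compounds shown leave open where any cytotoxic effect would begin and whether any structural change shifts it: the limit of > 26000 nM in this assay, at which 3 of the 3 values shown sit.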